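The source may report more compounds than this note shows. Statements on the series, on what has been measured and on what is new or still open speak of the compounds shown alone.

Measured so far in a functional assay (RXF 631 cells, Homo sapiens) for inhibition, read by colorimetric assay and sulforhodamine B assay, with a stated time of 48 h; on this read-out higher numbers stand for weaker inhibition of growth and lower numbers for stronger inhibition of growth:
- compound 1 `CCCCCCCCCCCC[C@@H](O)[C@H]1CC[C@H]([C@H](O)CCCCCCCCCCNC(=O)c2cccs2)O1`: 3240 nM
- compound 2 `CCCCCCCCCCCC[C@@H](O)[C@H]1CC[C@H]([C@H](O)CCCCCCCCCCNC(=O)c2ccsc2)O1`: 100000 nM

Compound 2, at 100000 nM, has the higher of the two numbers in this assay. Compound 3 `CCCCCCCCCCCC[C@@H](O)[C@H]1CC[C@H]([C@H](O)CCCCCCCCCCNC(=O)c2ccnn2C)O1` differs from it at one place: 1-methyl-1H-pyrazol-5-yl in place of thiophen-3-yl on a carbonyl carbon. In words, this is 1-methyl-1H-pyrazol-5-yl in place of thiophen-3-yl on a carbonyl carbon.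

Among the measured compounds shown here, only one measured step bears on this change, a 31-fold higher number from compound 1 to compound 2 (1.49 log units; beyond the scatter). It is large and shows that swapping the group on the carbonyl carbon can move the number well beyond the scatter. For the measured compounds named here, no measured compound carries 1-methyl-1H-pyrazol-5-yl, so the direction is uncertain. With compound 2 at the top of this short series, a sizeable drop is expected. The expected change is a 13-fold lower number from compound 2 to compound 3 (1.10 log units; beyond the scatter). For compound 3 the estimated value is 8000 nM, with an expected range of 2000 nM to 50000 nM.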

Compound 3, concentration for 50% growth inhibition: 100000 nM
Compound 3: the middle estimate sits 13-fold (1.10 log units) below what was measured; the whole stated range lies below it.
By their numbers in this assay, from the lowest: compound 1; then compounds 2 and 3 (each within the scatter of the next).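

In this assay, the change on the carbonyl carbon gives no change at the digits printed from compound 2 to compound 3 (within the scatter), so a second ring with a different hetero atom set, 1-methyl-1H-pyrazol-5-yl, reads the same as thiophen-3-yl. Among the compounds shown here, the comparison with thiophen-2-yl gives a 31-fold higher number from compound 1 to compound 3 (1.49 log units; beyond the scatter), which matches a 31-fold higher number from compound 1 to compound 2 (1.49 log units; beyond the scatter) and leaves thiophen-2-yl as the only one of the three rings with the lower number. No measured evidence here accounts for this difference among the rings.

As far as these compounds go, it remains open whether the lower number is confined to thiophen-2-yl or also appears with furan-2-yl, phenyl or 1-methyl-1H-pyrrol-2-yl on the same carbonyl carbon. Also open, from the compounds shown here alone, is how a shorter or longer chain between the amide nitrogen and the shared core would shift the number with thiophen-2-yl in place.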